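Compound 4 and the Shift from 3-Chlorobenzyl to 4-Chlorobenzyl

A few compounds are considered here, and "the series" means these few. Any claim that something is new, unique, unknown or untested is made for them only; others in the source may bear on it.

Of the compounds shown here, three built on one shared core have been tested in a functional assay on the whole organism (artery, strain albino) with Rattus norvegicus as the target, with a stated time of 120 min, at a dose of 10 mg/kg by the oral route; on this read-out higher numbers stand for more inhibition at the one dose given (going by the name of the read-out) and lower numbers for less inhibition. Compound 1 `COc1ccc(C2N=C(SCc3ccc(Cl)cc3)NC(C)=C2C(=O)Nc2ccc(F)cc2)cc1OC` gives 15.5% in this assay. Compound 2 `CC1=C(C(=O)Nc2ccc(F)cc2)C(c2ccc([N+](=O)[O-])cc2)N=C(SCc2ccccc2Cl)N1` gives 8.8%, and compound 3 `CC1=C(C(=O)Nc2ccc(F)cc2)C(c2ccc([N+](=O)[O-])cc2)N=C(SCc2cccc(Cl)c2)N1` gives 9.8%, the second highest of the three numbers; its nearest neighbour is compound 2 and its furthest compound 1, both gaps within the scatter. Within the data shown here, the single measured step that alters one place, a number 1 percentage points higher from compound 2 to compound 3 (within the scatter), moved the chlorine on the chlorophenyl sitting on a saturated chain carbon bound to a sulfur. Compound 4 `CC1=C(C(=O)Nc2ccc(F)cc2)C(c2ccc([N+](=O)[O-])cc2)N=C(SCc2ccc(Cl)cc2)N1` carries the same kind of change: 4-chlorophenyl in place of 3-chlorophenyl on a saturated chain carbon bound to a sulfur. Because the earlier step of a number 1 percentage points higher from compound 2 to compound 3 (within the scatter) remained within the scatter, the step of a number 1.2 percentage points higher from compound 3 to compound 4 (within the scatter) is expected to remain within it too. Compound 4 is therefore estimated at 11%, with a range from 3% to 19%.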

Compound 4, a percentage reported as inhibition, in the whole organism at one dose (the size of the read-out at that dose, not a potency): 16%
Beside the measured number, compound 4's estimate is 5 percentage points below it, and the stated range covers the measured number.
By their numbers in this assay, from the lowest: compounds 2, 3, 1 and 4 (each within the scatter of the next).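

In this assay, with 2-chlorophenyl, 3-chlorophenyl and 4-chlorophenyl all now measured on a saturated chain carbon bound to a sulfur, both a number 6.2 percentage points higher from compound 3 to compound 4 (within the scatter) and a number 7.2 percentage points higher from compound 2 to compound 4 (within the scatter) stay in range, so these numbers separate none of the three. With 4-chlorophenyl on that carbon, a number 0.5 percentage points higher from compound 1 to compound 4 (within the scatter) likewise separates neither 4-nitrophenyl nor 3,4-dimethoxyphenyl on a saturated ring carbon. Nothing measured here bears on why these numbers fall as they do. On these data alone, whether a methoxy group or a carboxylic acid in place of the chlorine would leave this range remains open. So does the effect of a longer chain between the sulfur and the phenyl ring.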